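This account rests on a few compounds, and the source may have more. Where it says the series, first, only, none or still open, it means among the compounds named here.

Series on a shared core: compound 1 `CC(=O)N[C@@H]1CCN(c2cc(C)nn3c(-c4ccccc4)c(C)nc23)C1`, compound 2 `CC(=O)N[C@@H]1CCN(c2cc(C)nn3c(-c4ccc(C(F)(F)F)cc4)c(C)nc23)C1`, compound 3 `CCCCCC(=O)N[C@@H]1CCN(c2cc(C)nn3c(-c4ccc(OC)c(OC)c4)c(C)nc23)C1`. In an ADME assay on microsomes from liver (Mus musculus) for metabolic stability, read by LC-MS, with NADPH named in the record, with a stated time of 60 min, tested at 1 uM, in the absence of a further agent (a higher number here means that more of the compound is left, a lower number that less of the compound is left), compound 1 returns only a limit, > 95%. Compound 2 likewise returns a limit in this assay, > 95%. Compound 3 stands at a limit too in this assay, giving > 95%. For the measured compounds named here, the one step between measured neighbours, a step that the two limits leave unreadable from compound 1 to compound 2, is therefore of unreadable size, since all three values sit at the limit of > 95% in this assay, at which 3 of the 3 values shown sit. Compound 4 `COc1ccc(-c2c(C)nc3c(N4CC[C@@H](NS(=O)(=O)c5ccc(C)cc5)C4)cc(C)nn23)cc1OC` is not yet measured and differs from compound 3 by (4-methylphenyl)sulfonyl in place of pentylcarbonyl on an amine nitrogen. Going by the values given here, no measured step bears on this change. Compound 4 is expected to stay at the limit in this assay, estimated at 93% with a range of 75% to 100%. The expected step of a number at least 2 percentage points lower from compound 3 to compound 4 (that floor lies within the scatter) is accordingly none beyond the scatter.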

Compound 4, percent of the compound remaining: > 95%
Compound 4 gave a limit, no number; the forecaster's own chance of this, stated with the estimate: 65%; middle value at least 2 percentage points away from the limit.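

No step can be read from compound 3 to compound 4, as both give only a limit in this assay: the limit of > 95% in this assay, at which 4 of the 4 values shown sit.

The compounds shown leave open whether any of these changes moves the percent remaining, with no numerical value yet to compare.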